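Disulfide nucleoside analogues: cytotoxicity on a leukaemia cell line

The source may report more compounds than this note shows. Statements on the series, on what has been measured and on what is new or still open speak of the compounds shown alone.

Measured so far:
- compound 1, `CSS[C@H]1C[C@H](n2ccc(N)nc2=O)O[C@@H]1CO`: 111000 nM
- compound 2, `Cc1cn([C@H]2C[C@H](SSc3ccc([N+](=O)[O-])cc3)[C@@H](CO)O2)c(=O)[nH]c1=O`: 23000 nM

In an ADME assay on CCRF-CEM cells (Homo sapiens) for cytotoxicity (on this read-out lower numbers stand for higher toxicity in this test and higher numbers for lower toxicity in this test), compound 2 gives the lowest of the two numbers, and compound 1 sits higher by a margin that is beyond the scatter, so compound 2 is the more toxic of the two in this assay. Among the measured compounds shown here, the two compounds differ in more than one place, so no single step between them can be drawn; only the two values themselves are known.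

Compound 3, `Cc1cn([C@H]2C[C@H](SSCCCCCCO)[C@@H](CO)O2)c(=O)[nH]c1=O`, has not yet been measured. It differs from compound 2 in one place: 6-hydroxyhexyl in place of 4-nitrophenyl on a sulfur. For the measured compounds named here, no step between measured compounds is known, so the expected size rests on the position of compound 2 alone. For compound 3 the step of a 2.6-fold higher number from compound 2 to compound 3 (0.42 log units; beyond the scatter) is expected to go toward a higher number, modest in size and possibly not beyond the scatter. Compound 3 is estimated at 60000 nM, with a range from 20000 nM to 200000 nM.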

Compound 3, half-maximal cytotoxic concentration: 52000 nM
For compound 3 the middle estimate is 1.2-fold (0.06 log units) above the measured one; low and high end bracket the measured number.
By their numbers in this assay, from the lowest: compound 2; then compound 3; then compound 1.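

In this assay, the group on a sulfur proves able to shift the read-out: 6-hydroxyhexyl in place of 4-nitrophenyl gives a 2.3-fold higher number from compound 2 to compound 3 (0.35 log units; beyond the scatter), a modest step but beyond the scatter, toward lower toxicity in this test. Among the compounds shown here, this is the first single change that can be read, as the earlier pair differed in more than one place, and it shows that an aromatic group on this sulfur is not needed for a measurable cytotoxic read-out. Nothing at hand bears on what lies behind the step.

From the compounds shown here alone, the change removes the 4-nitrophenyl ring and brings in a chain with a hydroxyl at once, so the share of each stays open. A plain hexyl chain, an unsubstituted phenyl, or an amine in place of the hydroxyl would separate these contributions.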